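Working notes on compounds 1 to 3 in the binding series

The source may report more compounds than this note shows. Statements on the series, on what has been measured and on what is new or still open speak of the compounds shown alone.

Measured so far:
compound 1, `CCCn1c(=O)c2[nH]c(-c3ccc(S(=O)(=O)N4CCN(c5ccc(Cl)cc5)CC4)cc3)nc2n(CC)c1=O`, in an assay on CHO cells for displacement of a labelled ligand from adenosine receptor A1 (Homo sapiens), read by scintillation counting, with a stated time of 90 min, in the presence of a further agent that is not named here (on this read-out higher numbers stand for weaker inhibition and lower numbers for stronger inhibition), gives > 1000 nM, which is a limit of the assay and not a number.
compound 2, `CCCn1c(=O)[nH]c2nc(-c3ccc(S(=O)(=O)N4CCN(c5ccccc5Cl)CC4)cc3)[nH]c2c1=O`, in this assay gives > 1000 nM, again a limit of the assay.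

Among the measured compounds shown here, compound 2 therefore stands at the limit of > 1000 nM in this assay, at which 2 of the 2 values shown sit, and the one further value shown sits at that same limit. For the measured compounds named here, neither measured compound carries a number, so no step between them can be drawn and nothing here says how far either lies past the limit.

Compound 3, `CCCn1c(=O)[nH]c2nc(-c3ccc(S(=O)(=O)N4CCN(Cc5ccc(Br)c(F)c5)CC4)cc3)[nH]c2c1=O`, is the unmeasured member. It differs from compound 2 in one place: 4-bromo-3-fluorobenzyl in place of 2-chlorophenyl on an amine nitrogen in a ring.

Going by the values given here, with both measured values at the limit, the only guide to compound 3 is that the shared core with this sulfonyl-linked ring has given no measurable inhibition in either case. The step expected from compound 2 to compound 3 is a step that the limit leaves unreadable from compound 2 to compound 3, which is taken as none beyond the scatter. Compound 3 in this assay is thus expected at about 3000 nM, within 1000 nM to 10000 nM, with a limit rather than a number the likely report.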

Compound 3, inhibition constant: 326 nM
Compound 3: the middle estimate sits 9.2-fold (0.96 log units) above what was measured; the measured number lies below the stated range.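

At the amine nitrogen in the six-membered ring with 2 nitrogen, the group decides whether a number can be read at all: in this assay, 4-bromo-3-fluorobenzyl in place of 2-chlorophenyl gives an at least 3.0-fold lower number from compound 2 to compound 3 (0.48 log units; beyond the scatter), so this position can carry a change beyond the scatter, and the shared core with its sulfonyl-linked ring is not bound to stay at the limit. The value of compound 2, > 1000 nM, is a limit of the assay and not a number. The step is therefore a minimum, and its full size cannot be read: the limit of > 1000 nM in this assay, at which 2 of the 3 values shown sit.

The change swaps the whole group at once, so the part played by the benzyl form and the part played by the bromine and fluorine cannot be separated without a plain benzyl or a 2-chlorobenzyl on the same nitrogen. Also open, going by these compounds, is how this nitrogen would read with a group that has no aromatic ring, such as cyclohexyl or a longer alkyl chain.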